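A few compounds are considered here, and "the series" means these few. Any claim that something is new, unique, unknown or untested is made for them only; others in the source may bear on it.

- compound 1 `CCCCCc1ccc(-c2cn(CCCN3C(=O)COc4ccccc43)nn2)cc1`: > 100000 nM, a limit of the assay and not a number
- compound 2 `O=C1COc2ccccc2N1CCCn1cc(-c2ccccn2)nn1`: 10000 nM
- compound 3 `O=C1COc2ccccc2N1CCCn1cc(CCCCl)nn1`: not yet measured

Within the data shown here, in a functional assay on HeLa cells (Homo sapiens) for antiproliferative activity, read by sulforhodamine B assay, with a stated time of 48 h (on this read-out higher numbers stand for weaker inhibition of growth and lower numbers for stronger inhibition of growth), compound 2 gives 10000 nM, the only exact number so far. Compound 1 offers only its limit, (the limit of > 100000 nM in this assay, at which 1 of the 2 values shown sits).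

Compound 3 keeps the shared core but carries 3-chloropropyl in place of pyridin-2-yl on an aromatic carbon. Among the measured compounds shown here, no pair of measured compounds shows what such a swap does, so any forecast is rough. Starting from compound 2 at 10000 nM, a modest move towards weaker inhibition of growth is expected in this assay. A result at the limit of the assay remains possible for compound 3. The expected change is a 2.0-fold higher number from compound 2 to compound 3 (0.30 log units; within the scatter). For compound 3 the estimated value is 20000 nM, with an expected range from 6000 nM to 80000 nM.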

Compound 3, concentration for 50% growth inhibition: 100 nM
Compound 3: middle estimate off by 200-fold (2.30 log units), on the high side; measured number outside the range, below it.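

Among these compounds, replacing pyridin-2-yl with 3-chloropropyl on this aromatic carbon of the five-membered aromatic ring brings a 100-fold lower number from compound 2 to compound 3 (2.00 log units; beyond the scatter) in this assay and gives the first measured step. It shows that this position strongly affects the read-out, and that a group with no ring can give much stronger inhibition of growth here than pyridin-2-yl does. Compound 1 still cannot be placed exactly on this scale, since its value is a limit of the assay and not a number: the limit of > 100000 nM in this assay, at which 1 of the 3 values shown sits.

This single step cannot separate the effect of losing the ring from the effect of adding the chlorine. A plain propyl chain, a longer chain ending in chlorine, or a propyl chain ending in an amine would help to tell these apart.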